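This account rests on a few compounds, and the source may have more. Where it says the series, first, only, none or still open, it means among the compounds named here.

In an ADME assay on cells (Hepatocyte, Mus musculus) for metabolic stability, with a stated time of 30 min (on this read-out higher numbers stand for a more stable compound and lower numbers for a less stable compound), compound 2 `O=C(OC1CCC(CN2CCN(c3cc(=O)c4cc(C(F)(F)F)cc([N+](=O)[O-])c4s3)CC2)CC1)c1ccco1` is the lower of the two measured compounds at 0.6%, against compound 1 `NC1CCC(CN2CCN(c3cc(=O)c4cc(C(F)(F)F)cc([N+](=O)[O-])c4s3)CC2)CC1` at 107%. Compound 3 `O=C(OC1CCC(CN2CCN(c3cc(=O)c4cc(C(F)(F)F)cc([N+](=O)[O-])c4s3)CC2)CC1)C1CCCCC1` has cyclohexyl in place of furan-2-yl on a carbonyl carbon. Among the measured compounds shown here, the only measured step, a number 106.4 percentage points lower from compound 1 to compound 2 (beyond the scatter), is large but exchanged amino for ((furan-2-yl)carbonyl)oxy, and compound 3 also lacks the amino. For the measured compounds named here, no measured step covers the present exchange, so only a small upward step in this assay is expected, probably within the scatter. The estimated step is a number 3.4 percentage points higher from compound 2 to compound 3 (within the scatter). For compound 3 the expected value is 4%, with an estimated range of 0.5% to 20%.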

Compound 3, percent of the compound remaining: 1.2%
Beside the measured number, compound 3's estimate is 2.8 percentage points above it; the range from low to high includes it.
By their numbers in this assay, from the lowest: compounds 2 and 3 (each within the scatter of the next); then compound 1.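

In this assay, cyclohexyl on the carbonyl carbon gives a number 0.6 percentage points higher from compound 2 to compound 3 (within the scatter), so replacing the aromatic furan-2-yl ring with a non-aromatic carbon ring leaves the number unmoved. With (cyclohexylcarbonyl)oxy there is a number 105.8 percentage points lower from compound 1 to compound 3 (beyond the scatter), so the large step is not confined to the furan-2-yl group. Nothing available bears on why these numbers lie where they do. Still open, from the compounds shown here alone, is whether the low numbers belong to the oxygen-linked carbonyl as such. A plain hydroxyl or an amide on the saturated ring carbon would address this.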